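From methyl to cyano: compound 3 to compound 4

A few compounds are considered here, and "the series" means these few. Any claim that something is new, unique, unknown or untested is made for them only; others in the source may bear on it.

In a functional assay on RAW264.7 cells (Mus musculus) for inhibition, read by Griess assay, with stated times of 1 h and 24 h (a higher number here means a weaker inhibitor, a lower number a stronger inhibitor), compound 1 (`COc1ccc(C(O)C2OC(=O)c3c(OC)cc(OC)cc32)cc1`) reads > 10000 nM as a limit of the assay and not a number. Compound 2 (`COc1cc(OC)c2c(c1)C(C(O)c1ccc(OCc3ccc(Cl)cc3)cc1)OC2=O`) reads 4320 nM in this assay and carries a 4-chlorophenyl group in place of a hydrogen of compound 1. Compound 3 (`COc1cc(OC)c2c(c1)C(C(O)c1ccc(OCc3ccc(C)cc3)cc1)OC2=O`) reads 3120 nM and carries 4-methylphenyl there. Among the measured compounds shown here, compound 3 holds the lowest number so far, but its lead over the only other numerical value lies within the scatter (a 1.4-fold lower number from compound 2 to compound 3 (0.14 log units; within the scatter)). Both compounds stand clear of the limit (an at least 2.3-fold lower number from compound 1 to compound 2 (0.36 log units; beyond the scatter)) and (an at least 3.2-fold lower number from compound 1 to compound 3 (0.50 log units; beyond the scatter)).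

Compound 4 (`COc1cc(OC)c2c(c1)C(C(O)c1ccc(OCc3ccc(C#N)cc3)cc1)OC2=O`) differs from compound 3 in one group: cyano in place of methyl on an aromatic carbon, para to a large group, which turns 4-methylbenzyl into 4-cyanobenzyl (cyano in place of methyl on an aromatic carbon). For the measured compounds named here, no measured compound carries cyano. The closest evidence is the exchange at the same place, methyl in place of chloro, which gave compound 3 its step (a 1.4-fold lower number from compound 2 to compound 3 (0.14 log units; within the scatter)) and stayed within the scatter. The larger steps from compound 1 add the whole group and say little about this exchange. No step beyond the scatter is therefore expected in this assay and no direction is favoured.

Going by the values given here, the estimate for compound 4 is 3500 nM with an expected range of 1500 nM to 8000 nM on the numbers so far. That estimate means a 1.1-fold higher number from compound 3 to compound 4 (0.05 log units; within the scatter) as the expected step.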

Compound 4, half-maximal inhibitory concentration: 7360 nM
Compound 4: middle estimate off by 2.1-fold (0.32 log units), on the low side; the range from low to high includes it.
By their numbers in this assay, from the lowest: compounds 3, 2 and 4 (each within the scatter of the next, the first and the last beyond it). At a limit, above all of these: compound 1.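

In this assay, the exchange at the aromatic carbon para to a large group now has a step beyond the scatter: a 2.4-fold higher number from compound 3 to compound 4 (0.37 log units; beyond the scatter). This shows that the position is not indifferent to its substituent, although the change from 4-methylbenzyl to 4-cyanobenzyl is only modest in size, and the chloro compound does not separate from the cyano compound (a 1.7-fold higher number from compound 2 to compound 4 (0.23 log units; within the scatter)), so only the methyl and cyano pair stands apart among the three groups at this carbon. The step of an at least 1.3-fold lower number from compound 1 to compound 4 (0.13 log units; that floor lies within the scatter) gives no size and keeps compound 4 within the scatter of that floor, since compound 1 stands at a limit and not at a number: the limit of > 10000 nM in this assay, at which 1 of the 4 values shown sits.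

Among the compounds shown here, the series so far carries only methyl, chloro and cyano at this carbon, which is too few to tie the change in number to any one feature of the group, and the data give no cause for it. On these data alone, whether an amine, a methoxy group or a carboxylic acid at this carbon would bring the number clearly below those of compound 2 and compound 3 remains open.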